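Bromo to fluoro swap on the shared core: cytotoxicity

The source may hold more compounds than are shown below. What is called first, only, known or untested is meant among the compounds shown, and "the series" means these compounds.

Measured compounds:
- compound 1, `O=C(COc1cccc2ccccc12)N/N=C/c1ccccc1Br`; in an ADME assay on HEL cells (Homo sapiens) for cytotoxicity (a lower number here means that less compound is tolerated, a higher number that more compound is tolerated), compound 1 gives >= 20 ug/mL, which is a limit of the assay and not a number.
- compound 2, `O=C(COc1cccc2ccccc12)N/N=C/c1ccccc1[N+](=O)[O-]`; in this assay compound 2 gives 20 ug/mL.

Compound 1 stands at the limit of >= 20 ug/mL in this assay, at which 1 of the 2 values shown sits, so only a limit is known for it. For the measured compounds named here, the one measured step is a number no higher from compound 1 to compound 2 (the limit leaves the size open); its size is not readable, and it concerns a different change from the one considered here.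

Compound 3, `O=C(COc1cccc2ccccc12)N/N=C/c1ccc(F)cc1`, is the next compound for this assay. It differs from compound 1 as follows: 4-fluorophenyl in place of 2-bromophenyl on a carbon with a double bond to nitrogen.

Going by the values given here, no measured step bears on the change to 4-fluorophenyl; the nitro-for-bromo step gives no readable size either. With nothing to point in either direction, the expectation is a step from compound 1 to compound 3 of about a number no higher from compound 1 to compound 3 (the limit leaves the size open), that is, no shift beyond the usual scatter. For compound 3 the estimate in this assay is 20 ug/mL, within a range from 10 ug/mL to 40 ug/mL.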

Compound 3, minimum cytotoxic concentration: 100 ug/mL
Estimate against measurement, compound 3: 5.0-fold (0.70 log units) below; the measured number lies above the stated range.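

The step from compound 1 to compound 3 in this assay cannot be read, because compound 1 is known only as a limit of the assay: the limit of >= 20 ug/mL in this assay, at which 1 of the 3 values shown sits. The compounds shown leave open whether 4-fluorophenyl in place of 2-bromophenyl changes the tolerated concentration at all and, with halogen and its place changing together, which of the two would matter.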